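Swapping the aryl group on the amino nitrogen

This account rests on a few compounds, and the source may have more. Where it says the series, first, only, none or still open, it means among the compounds named here.

In a functional assay on HeLa cells (Homo sapiens) for antiproliferative activity, read by MTT assay, with a stated time of 48 h (on this read-out higher numbers stand for weaker inhibition and lower numbers for stronger inhibition), compound 2 (`C#Cc1cccc(Nc2ncnc3sc(NC(=O)/C=C/c4ccccc4)cc23)c1`) stands highest of the two measured compounds at 4640 nM, while compound 1 (`O=C(/C=C/c1ccccc1)Nc1cc2c(Nc3ccc(F)c(Cl)c3)ncnc2s1`) gives 2140 nM. Compound 3 (`O=C(/C=C/c1ccccc1)Nc1cc2c(Nc3cc(Cl)cc(Cl)c3)ncnc2s1`) carries 3,5-dichlorophenyl in place of 3-ethynylphenyl on a nitrogen on an aromatic ring. Among the compounds with values here, the only measured step that bears on this change is modest: a 2.2-fold higher number from compound 1 to compound 2 (0.34 log units; beyond the scatter), with 3-ethynylphenyl entering in place of 3-chloro-4-fluorophenyl. This single pair suggests a similarly modest move toward a lower number in this assay, and the expected change is a 1.7-fold lower number from compound 2 to compound 3 (0.22 log units; within the scatter). The estimate for compound 3 is 2800 nM, with an expected range of 1200 nM to 6500 nM.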

Compound 3, half-maximal inhibitory concentration: 4 nM
Compound 3: middle estimate off by 700-fold (2.85 log units), on the high side, and the stated range ends above it.
By their numbers in this assay, from the lowest: compound 3; then compound 1; then compound 2.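

At this position the aryl group on the nitrogen matters far more than the first pair showed, with a 1200-fold lower number from compound 2 to compound 3 (3.06 log units; beyond the scatter) in this assay and a 540-fold lower number from compound 1 to compound 3 (2.73 log units; beyond the scatter) on the same read-out. The leaving and entering groups both count 8 heavy atoms, so that count does not separate compound 2 from compound 3. Nothing at hand accounts for the size of these steps.

Going by these compounds, whether both chlorine atoms are needed remains open. So does whether 3-chlorophenyl or 3,5-dimethylphenyl would give comparably low numbers in this assay on the same core.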